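The source may report more compounds than this note shows. Statements on the series, on what has been measured and on what is new or still open speak of the compounds shown alone.

Of the compounds shown here, three sharing one core have been measured in a functional assay on A549 cells (Homo sapiens) for inhibition, read by MTT assay, with a stated time of 72 h; a higher number here means a weaker inhibitor, a lower number a stronger inhibitor. Compound 1 `O=C(Nc1ccc(Oc2ccnc3[nH]ccc23)cc1)c1cn(-c2ccc(F)cc2)c2ccccc2c1=O` gives 390 nM, the lowest number of the three. Compound 2 `O=C(Nc1ccc(Oc2ccnc3[nH]ccc23)cc1)c1cn(-c2ccc(Br)cc2F)c2ccccc2c1=O` gives 1330 nM, and compound 3 `O=C(Nc1ccc(Oc2ccnc3[nH]ccc23)cc1)c1cn(-c2ccc(C(F)(F)F)cc2Cl)c2ccccc2c1=O` gives 2350 nM. Both departures from compound 1 sit on the ring attached to the aromatic nitrogen: the step of a 3.4-fold higher number from compound 1 to compound 2 (0.53 log units; beyond the scatter) and the step of a 6.0-fold higher number from compound 1 to compound 3 (0.78 log units; beyond the scatter) each weaken inhibition beyond the scatter, while the step of a 1.8-fold higher number from compound 2 to compound 3 (0.25 log units; within the scatter) stays within it.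

Compound 4 `O=C(Nc1ccc(Oc2ccnc3[nH]ccc23)c(F)c1)c1cn(-c2ccc(F)cc2)c2ccccc2c1=O` differs from compound 1 at a different place altogether: fluoro in place of hydrogen on an aromatic carbon, the carbon being part of a six-membered aromatic ring of carbon only, ortho to a large group and meta to a large group. Among the measured compounds shown here, none of the measured steps touches this ring, so none bears directly on the change; they show only that the series answers to small alterations elsewhere, and that the unchanged ring of compound 1 goes with the lowest number seen. For the measured compounds named here, with no direct precedent, the expectation is for a step of a 1.1-fold lower number from compound 1 to compound 4 (0.05 log units; within the scatter) in this assay that stays within the scatter. Compound 4 is therefore estimated at 350 nM, with a range from 150 nM to 900 nM.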

Compound 4, half-maximal inhibitory concentration: 290 nM
Estimate against measurement, compound 4: 1.2-fold (0.08 log units) above, within the range that was stated.
By their numbers in this assay, from the lowest: compounds 4 and 1 (each within the scatter of the next); then compounds 2 and 3 (each within the scatter of the next).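

In this assay, fluoro in place of hydrogen on this aromatic carbon, ortho to a large group and meta to a large group, gives a 1.3-fold lower number from compound 1 to compound 4 (0.13 log units; within the scatter) and so leaves the two compounds indistinguishable. Among the compounds shown here, this is the first view of the six-membered aromatic ring of carbon only, which stayed unchanged in the first three compounds, and it shows that this position accepts one fluoro with no change beyond the scatter, whereas both replacements of the ring on the aromatic nitrogen in compound 1 gave steps beyond it. Nothing available explains why this small substitution leaves the number within the scatter.

The compounds shown leave open whether this position would accept something larger than fluoro, such as chloro, methyl or methoxy, or a group of another kind, such as an amine. They also leave open whether the same fluoro would behave alike on the other carbons of this ring, or alongside the 4-bromo-2-fluorophenyl group of compound 2 in place of the 4-fluorophenyl group of compound 4.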